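Aminothiophene series: cyano to carbamoyl and lipophilicity

The compounds below may be only part of what the source reports. "The series", "measured", "known", "first", "only" and "open" are said of these compounds alone.

Measured compounds:
compound 1, `COC(=O)c1sc(Oc2ccccc2)c(C#N)c1N`, 3.66
compound 2, `Cc1cccc(Oc2sc(C(N)=O)c(N)c2C#N)c1`, 2.69
compound 3, `Cc1cccc(Oc2sc(C#N)c(N)c2C#N)c1`, 3.04

In a physicochemical assay for lipophilicity (on this read-out higher numbers stand for higher lipophilicity and lower numbers for lower lipophilicity), compound 1 gives the highest of the three numbers, with compound 3 nearer to it and compound 2 furthest off. The difference between the core of compound 1 and the core of compound 3 is not broken down here. Within the pair that shares a core, the change carbamoyl in place of cyano on an aromatic carbon gave a number 0.35 log units lower from compound 3 to compound 2 (beyond the scatter), a modest step beyond the scatter.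

Compound 4, `COC(=O)c1sc(Oc2ccccc2)c(C(N)=O)c1N`, is not yet measured. It carries the same kind of change relative to compound 1, (carbamoyl in place of cyano on an aromatic carbon). The place is not the same word for word: in compound 1 the changed carbon sits next to the ring atom that bears a group of 7 heavy atoms and two ring bonds from the ring sulfur, whereas in compound 3 it sits next to the ring sulfur and two ring bonds from the ring atom that bears a group of 8 heavy atoms.

For compound 4 a step of a number 0.35 log units lower from compound 1 to compound 4 (beyond the scatter) is expected, resting on the step of a number 0.35 log units lower from compound 3 to compound 2 (beyond the scatter) and on compound 1 at 3.66. Compound 4 is therefore estimated at 3.31, between 2.9 and 3.7.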

Compound 4, partition coefficient: 3.11
For compound 4 the middle estimate is 0.20 log units above the measured one; the measured number falls inside the stated range.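

In this assay, carbamoyl in place of cyano on an aromatic carbon gave a number 0.55 log units lower from compound 1 to compound 4 (beyond the scatter), and the same change on the other core gave a number 0.35 log units lower from compound 3 to compound 2 (beyond the scatter), so both available pairs run in the same direction and both steps are modest. This shows that the direction carried from one core to the other in these two pairs, but the two steps are not the same number, and two pairs that differ in both core and the place of the change cannot separate the contribution of either, nor do they establish a general rule for the series. No measurement available here bears on why the two steps differ in size.

The compounds shown leave open where a carboxylic acid or a primary amine in place of cyano would fall in this assay. Also open, going by these compounds, is whether the step keeps its direction on a core carrying a longer ester chain in place of the methoxycarbonyl group.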